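Carbonyl aryl swap from compound 2 to compound 3

The source may hold more compounds than are shown below. What is called first, only, known or untested is meant among the compounds shown, and "the series" means these compounds.

In an ADME assay on MT4 cells (Homo sapiens) for cytotoxicity, read by MTT assay (on this read-out lower numbers stand for higher toxicity in this test and higher numbers for lower toxicity in this test), compound 2 `O=C1c2ccccc2C(=O)N1CCOC(=S)N(C(=O)c1c(F)cccc1F)c1ccc(Cl)cc1` gives 39000 nM and compound 1 `Cc1cccc(C(=O)N(C(=S)OCCN2C(=O)c3ccccc3C2=O)c2ccc(Cl)cc2)c1` gives 58000 nM, so the two numbers lie within the scatter of each other. Compound 3 `O=C1c2ccccc2C(=O)N1CCOC(=S)N(C(=O)c1ccc(Cl)cc1Cl)c1ccc(Cl)cc1` differs from compound 2 as follows: 2,4-dichlorophenyl in place of 2,6-difluorophenyl on a carbonyl carbon. In words, 2,4-dichlorophenyl stands in place of 2,6-difluorophenyl on a carbonyl carbon. For the measured compounds named here, the only measured step at this place, a 1.5-fold lower number from compound 1 to compound 2 (0.17 log units; within the scatter), does not exceed the scatter. No step beyond the scatter is therefore expected in this assay, and no direction is favoured. The estimated step is a 1.1-fold lower number from compound 2 to compound 3 (0.05 log units; within the scatter). For compound 3 the expected value is 35000 nM, with an estimated range of 14000 nM to 85000 nM.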

Compound 3, half-maximal cytotoxic concentration: 18000 nM
Beside the measured number, compound 3's estimate is 1.9-fold (0.29 log units) above it; low and high end bracket the measured number.
By their numbers in this assay, from the lowest: compound 3; then compounds 2 and 1 (each within the scatter of the next).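

In this assay, the aryl group on the carbonyl carbon now gives steps beyond the scatter: 2,4-dichlorophenyl gives (a 2.2-fold lower number from compound 2 to compound 3 (0.34 log units; beyond the scatter)) against 2,6-difluorophenyl and (a 3.2-fold lower number from compound 1 to compound 3 (0.51 log units; beyond the scatter)) against 3-methylphenyl. Both steps are modest and point towards higher toxicity in this test, whereas compound 1 and compound 2 lie within the scatter of each other. No measurement at hand bears on the cause of this shift.

Compound 3 changes the halogen and its placement together, and these two changes remain unseparated. Also open, from the compounds shown here alone, is how an aminophenyl group or a longer alkyl chain would read at this carbonyl carbon.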